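Swapping iodo for fluoro on a methylamino compound

The source may report more compounds than this note shows. Statements on the series, on what has been measured and on what is new or still open speak of the compounds shown alone.

In an ADME assay on L6 cells (Rattus norvegicus) for cytotoxicity (on this read-out higher numbers stand for weaker inhibition and lower numbers for stronger inhibition), compound 2 (`CNc1nc(I)nc2c1ncn2[C@@H]1O[C@H](C)[C@@H](O)[C@H]1O`) gives 137000 nM as its value. Compound 3 (`CNc1nc(I)nc2c1ncn2[C@@H]1O[C@H](SC)[C@@H](O)[C@H]1O`) gives 120000 nM and sits level with it, while compound 1 (`C[C@H]1O[C@@H](n2cnc3c(N)nc(F)nc32)[C@H](O)[C@@H]1O`) gives the clearly lower 2100 nM on the same scale. Compound 4 (`CNc1nc(F)nc2c1ncn2[C@@H]1O[C@H](C)[C@@H](O)[C@H]1O`), still unmeasured, carries fluoro in place of iodo on an aromatic carbon, between two ring nitrogen atoms.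

Within the data shown here, the one measured step, a 1.1-fold lower number from compound 2 to compound 3 (0.06 log units; within the scatter), stays within the scatter, but it concerns a saturated ring carbon, so it says nothing direct about this swap. Among the measured compounds shown here, compound 1 is the only measured compound with fluoro on that aromatic carbon. It differs from compound 2 in more than this one place, so compound 1 with 2100 nM is only a loose guide, though it points toward lower numbers. The expected step in this assay is a 4.6-fold lower number from compound 2 to compound 4 (0.66 log units; beyond the scatter) and would mean stronger inhibition, an estimate resting on thin evidence. For compound 4 the estimated value is 30000 nM (expected range 4000 nM to 150000 nM).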

Compound 4, half-maximal inhibitory concentration: 236000 nM
The estimate for compound 4 lay 7.9-fold (0.90 log units) below the measured number; the whole stated range lies below it.
By their numbers in this assay, from the lowest: compound 1; then compounds 3, 2 and 4 (each within the scatter of the next).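

On this aromatic carbon, between two ring nitrogen atoms, fluoro in place of iodo makes no readable difference in this assay while the methylamino group stays, the result being a 1.7-fold higher number from compound 2 to compound 4 (0.24 log units; within the scatter). The large difference lies instead in another single change, methyl in place of hydrogen on the nitrogen, which gives a 110-fold higher number from compound 1 to compound 4 (2.05 log units; beyond the scatter), meaning much weaker inhibition with fluoro kept in place. The low number of compound 1 therefore goes with the hydrogen on that nitrogen rather than with fluoro, though nothing here explains either result.

Going by these compounds, whether the iodo and fluoro swap would stay as flat with hydrogen on that nitrogen remains open, since only the methylamino pair tests it. Also open, on these data alone, is how chloro or bromo on the aromatic carbon, or a longer chain such as ethyl on the nitrogen, would read on this scale.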